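The source may hold more compounds than are shown below. What is called first, only, known or untested is meant among the compounds shown, and "the series" means these compounds.

Measured so far:
Compound 1 `CCN(C(=O)c1cc(C(C)C)c(O)cc1O)c1ccc(NC(=O)CCCCCCC(=O)NO)cc1`: 1380 nM
Compound 2 `CC(C)c1cc(C(=O)Nc2cccc(NC(=O)CCCCCCC(=O)NO)c2)c(O)cc1O`: > 10000 nM
Compound 3 `CC(C)c1cc(C(=O)N(C)c2ccc(NC(=O)CCCCCCCCC(=O)NO)cc2)c(O)cc1O`: 210 nM

In a functional assay on NCI-H1975 cells (Homo sapiens) for inhibition, read by sulforhodamine B assay, with a stated time of 48 h (a higher number here means a weaker inhibitor of growth, a lower number a stronger inhibitor of growth), compound 1 gives 1380 nM, the higher of the two actual numbers, and compound 3 gives 210 nM. Compound 2 is reported only as a limit, > 10000 nM.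

Compound 4 `CC(C)c1cc(C(=O)Nc2ccc(NC(=O)CCCCCCC(=O)NO)cc2)c(O)cc1O`, not yet measured, has hydrogen in place of ethyl on an amide-type nitrogen. Compound 2 also has hydrogen on that nitrogen, though it differs from compound 4 elsewhere. The result for compound 2 is the limit > 10000 nM. On that single precedent, the expected change is a move toward a higher number, a weaker inhibitor of growth, estimated as a 3.6-fold higher number from compound 1 to compound 4 (0.56 log units; beyond the scatter). For compound 4 the estimated value is 5000 nM, with an expected range from 1800 nM to 10000 nM.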

Compound 4, concentration for 50% growth inhibition: > 10000 nM
Compound 4: a limit, no number; the forecaster's own chance of this, stated with the estimate: 30%; at least 2.0-fold (0.30 log units) between middle value and limit.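

Going by these compounds alone, compound 4 gives the first direct comparison at this nitrogen: in this assay, putting hydrogen in place of ethyl on the amide-type nitrogen gives an at least 7.2-fold higher number from compound 1 to compound 4 (0.86 log units; beyond the scatter), a step beyond the scatter. Compound 4 is reported as > 10000 nM, which is a limit, so the step gives only a minimum size: the limit of > 10000 nM in this assay, at which 2 of the 4 values shown sit.

The compounds shown leave open whether a larger group on this nitrogen, such as propyl or benzyl, would give a lower or a higher number than ethyl does.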